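Trifluoromethyl in place of methoxy: what to expect

The compounds below may be only part of what the source reports. "The series", "measured", "known", "first", "only" and "open" are said of these compounds alone.

In a functional assay on SGC-7901 cells (Homo sapiens) for antiproliferative activity, read by MTT assay, with a stated time of 48 h (a lower number here means that less compound is needed, a higher number that more compound is needed for the effect), compound 3 `COc1ccc(S(=O)(=O)N2N=C(C)CC2c2cc(Br)ccc2O)cc1` gives 21100 nM and compound 1 `CC1=NN(S(=O)(=O)c2ccc([N+](=O)[O-])cc2)C(c2cc(Br)ccc2O)C1` gives 27300 nM. These two lie within the scatter of each other, with a 1.3-fold lower number from compound 1 to compound 3 (0.11 log units; within the scatter). Compound 2 `CC1=NN(S(=O)(=O)c2ccc(F)cc2)C(c2cc(Br)ccc2O)C1` reaches only a limit, > 60000 nM.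

Compound 4 `CC1=NN(S(=O)(=O)c2ccc(C(F)(F)F)cc2)C(c2cc(Br)ccc2O)C1` carries trifluoromethyl in place of methoxy on an aromatic carbon, para to a large group (trifluoromethyl in place of methoxy on an aromatic carbon). Swaps at this same place can matter, as an at least 2.1-fold higher number from compound 1 to compound 2 (0.34 log units; beyond the scatter) and an at least 2.8-fold lower number from compound 2 to compound 3 (0.45 log units; beyond the scatter) show, though nitro and methoxy did not separate. Trifluoromethyl has not been measured here, so only a small move towards a higher number is expected, within the scatter: a 1.5-fold higher number from compound 3 to compound 4 (0.18 log units; within the scatter). Compound 4 is estimated at 32000 nM, with an expected range of 14000 nM to 60000 nM.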

Compound 4, half-maximal effective concentration: 16300 nM
Compound 4: the middle estimate sits 2.0-fold (0.29 log units) above what was measured; the range from low to high includes it.
By their numbers in this assay, from the lowest: compounds 4, 3 and 1 (each within the scatter of the next). At a limit, above all of these: compound 2.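

Trifluoromethyl does not separate from methoxy or nitro at this position, with a 1.3-fold lower number from compound 3 to compound 4 (0.11 log units; within the scatter) and a 1.7-fold lower number from compound 1 to compound 4 (0.22 log units; within the scatter), so in this assay these three groups give values within the scatter of one another. Fluoro alone stands apart, with an at least 3.6-fold lower number from compound 2 to compound 4 (0.56 log units; beyond the scatter). That step starts from compound 2, whose value is a limit of the assay and not a number: the limit of > 60000 nM in this assay, at which 1 of the 4 values shown sits.

As far as these compounds go, how far compound 2 really lies from the others stays open. So does whether an amine, a carboxylic acid or a longer chain at this position would match these three groups or fluoro.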